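Methoxy in place of nitro: what compound 4 may give

The compounds below may be only part of what the source reports. "The series", "measured", "known", "first", "only" and "open" are said of these compounds alone.

Compound 1, `O=C(/C=C\c1ccccc1)N1N=C(c2ccncc2)OC1c1c[nH]c2ccccc12`, in an ADME assay on PANC-1 cells (Homo sapiens) for cytotoxicity, read by MTT assay, with a stated time of 48 h (on this read-out higher numbers stand for weaker inhibition of growth and lower numbers for stronger inhibition of growth), compound 1 gives > 30 ug/mL, a limit of the assay.
Compound 2, `O=C(/C=C\c1ccc(O)cc1)N1N=C(c2ccncc2)OC1c1c[nH]c2ccccc12`, in this assay compound 2 gives > 30 ug/mL, a limit of the assay.
Compound 3, `O=C(/C=C\c1ccc([N+](=O)[O-])cc1)N1N=C(c2ccncc2)OC1c1c[nH]c2ccccc12`, in this assay compound 3 gives > 30 ug/mL, a limit of the assay.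

Compound 3 stands at the limit of > 30 ug/mL in this assay, at which 3 of the 3 values shown sit, so no number places it against the others. Compound 4, `COc1ccc(/C=C\C(=O)N2N=C(c3ccncc3)OC2c2c[nH]c3ccccc23)cc1`, differs from compound 3 by methoxy in place of nitro on an aromatic carbon. Within the data shown here, the steps that bear on this change are a step that the two limits leave unreadable from compound 1 to compound 3 and a step that the two limits leave unreadable from compound 2 to compound 3, and a step that the two limits leave unreadable from compound 1 to compound 2 is unreadable too: each end is a limit. No size or direction can be read from them, and the estimate rests on the shared limit alone. The step that the limit leaves unreadable from compound 3 to compound 4 is expected to stay within the scatter. Compound 4 is therefore expected to give 40 ug/mL, between 15 ug/mL and 100 ug/mL, most likely reported again only as a limit.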

Compound 4, concentration for 50% growth inhibition: > 30 ug/mL
Compound 4: only a limit was reported; the forecaster's own chance of this, stated with the estimate: 80%; the middle value lies beyond the limit too.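

In this assay compound 4 gives > 30 ug/mL, a limit of the assay, so no step from compound 1, compound 2 or compound 3 to compound 4 can be read: the limit of > 30 ug/mL in this assay, at which 4 of the 4 values shown sit.

The compounds shown leave open how strongly any of them inhibits growth, and whether hydroxy, nitro or methoxy changes that at all.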